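The source may hold more compounds than are shown below. What is called first, only, known or untested is meant among the compounds shown, and "the series" means these compounds.

For the measured compounds named here, in a functional assay on HL-60 cells (Homo sapiens) for inhibition, read by MTT assay, with a stated time of 72 h (on this read-out lower numbers stand for stronger inhibition and higher numbers for weaker inhibition), compound 1 (`COc1ccc(-c2nc(C)oc2C(=O)N2CCN(c3cccc(Cl)c3)CC2)cc1OC`) is reported as "not active" (no number reported), while compound 2 (`Cc1nc(-c2cccc(F)c2)c(C(=O)N2CCN(c3cccc(Cl)c3)CC2)o1`) gives 33.7 nM, the only number available so far. Compound 3 (`COc1cc(OC)cc(N2CCN(C(=O)c3oc(C)nc3-c3cccc(F)c3)CC2)c1`) differs from compound 2 in one place: 3,5-dimethoxyphenyl in place of 3-chlorophenyl on an amine nitrogen in a ring, with 3,5-dimethoxyphenyl in place of 3-chlorophenyl on an amine nitrogen in a ring. Going by the values given here, no measured step bears on this change, so only an expectation can be offered: a moderate weakening in this assay, somewhat beyond the scatter. The estimated change is a 3.0-fold higher number from compound 2 to compound 3 (0.47 log units; beyond the scatter). For compound 3 the expected value is 100 nM, with an estimated range of 20 nM to 500 nM.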

Compound 3, half-maximal inhibitory concentration: 28.2 nM
For compound 3 the middle estimate is 3.5-fold (0.55 log units) above the measured one, and the stated range covers the measured number.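

In this assay the change gives a 1.2-fold lower number from compound 2 to compound 3 (0.08 log units; within the scatter) and so separates 3,5-dimethoxyphenyl from 3-chlorophenyl at this place no more than repeat measurements would, even though the entering group has more heavy atoms and carries hydrogen-bond acceptors that 3-chlorophenyl lacks. For the compounds shown here, this is the first step readable at this place, as the earlier compounds gave only one number and no comparison. Nothing measured here accounts for this result. As far as these compounds go, it remains open whether a benzyl group or a pyridyl ring on the same nitrogen would also stay within the scatter of compound 2.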